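A few compounds are considered here, and "the series" means these few. Any claim that something is new, unique, unknown or untested is made for them only; others in the source may bear on it.

Compound 2 `CCCCc1ccc2[nH]cc(C(=O)OC)c(=O)c2c1` gives > 20000 nM in an ADME assay on J774 cells (Mus musculus) for cytotoxicity (a higher number here means that more compound is needed for the effect, a lower number that less compound is needed), and this entry is a limit of the assay, not a number. Its exact position is therefore unknown. Compound 3 `COC(=O)c1c[nH]c2cc(OCCCc3ccccc3)ccc2c1=O` does give a number in this assay, at 1480 nM. Compound 1 `CCCCc1cc2c(=O)c(C(C)=O)c[nH]c2cc1OCCOc1ccccc1` adds nothing here, as its entry is "not determined" (no result reported).

Compound 4 `COC(=O)c1c[nH]c2ccc(-c3ccccc3)cc2c1=O` keeps the shared core of compound 2 and changes one group: phenyl in place of butyl on an aromatic carbon. In short, phenyl takes the place of butyl on an aromatic carbon. For the measured compounds named here, no measured pair shows this change alone, so any forecast is rough. Going by the values given here, the only guide is that compound 3, which also carries a phenyl ring, though on a longer side chain, reads 1480 nM. A moderate move toward lower numbers therefore seems likely, but compound 4 could still end up reported only as a limit. The expected change is an at least 2.0-fold lower number from compound 2 to compound 4 (0.30 log units; that floor lies within the scatter). For compound 4 the estimated value is 10000 nM, with an expected range from 3000 nM to 30000 nM.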

Compound 4, half-maximal effective concentration: > 20000 nM
Compound 4 was reported as a limit; the forecaster's own chance of this, stated with the estimate: 40%; at least 2.0-fold (0.30 log units) between middle value and limit.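

In this assay, compound 2 and compound 4 are both reported only as limits, so no step can be read between them: the limit of > 20000 nM in this assay, at which 2 of the 4 values shown sit.

On these data alone, whether phenyl in place of butyl on an aromatic carbon changes the number at all, and in which direction, stays open.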